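The source may report more compounds than this note shows. Statements on the series, on what has been measured and on what is new or still open speak of the compounds shown alone.

Compound 1 `FC(F)(F)c1ccccc1-c1nc(NCc2ccc(Cl)cc2)c2ccccc2n1` gives 4800 nM in an assay on a protein complex for inhibition of ubiquitin carboxyl-terminal hydrolase 1/WD repeat-containing protein 48 (Homo sapiens), read by fluorescence; a higher number here means a weaker inhibitor, a lower number a stronger inhibitor. Two analogues with the same core have been run in this assay: compound 2 `FC(F)(F)c1ccccc1-c1nc(NCc2ccc(-c3ccccc3)cc2)c2ccccc2n1` gives 3700 nM, and compound 3 `FC(F)(F)c1cc(-c2ccc(CNc3nc(-c4ccccc4C(F)(F)F)nc4ccccc34)cc2)ccn1` gives 4900 nM. Compound 1 sits as the second highest of these three numbers, but every gap here is within the scatter, so no ordering among them can be read: the move a 1.3-fold lower number from compound 1 to compound 2 (0.11 log units; within the scatter), the move a 1.0-fold higher number from compound 1 to compound 3 (0.01 log units; within the scatter) and the move a 1.3-fold higher number from compound 2 to compound 3 (0.12 log units; within the scatter) all fall inside the usual spread of repeated measurements.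

Compound 4 `FC(F)(F)c1ccccc1-c1nc(NCc2ccc(C3CCCCC3)cc2)c2ccccc2n1` is not yet measured. Relative to compound 1 the change is cyclohexyl in place of chloro on an aromatic carbon. The step that bears most directly on it is the one with phenyl in place of chloro at the same position, which gave a 1.3-fold lower number from compound 1 to compound 2 (0.11 log units; within the scatter), and the aryl replacement in compound 3 likewise stayed within the scatter. Since neither replacement at this position moved this assay beyond the scatter, no step beyond the scatter is expected from compound 1 to compound 4, and the estimated step is a 1.1-fold lower number from compound 1 to compound 4 (0.06 log units; within the scatter). Compound 4 is therefore expected to give 4200 nM in this assay, with a range from 2000 nM to 9000 nM.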

Compound 4, half-maximal inhibitory concentration: 9800 nM
Compound 4: middle estimate off by 2.3-fold (0.37 log units), on the low side; the measured number lies above the stated range.
By their numbers in this assay, from the lowest: compounds 2, 1, 3 and 4 (each within the scatter of the next, the first and the last beyond it).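

At this position, on an aromatic carbon, the replacement is no longer silent in this assay: cyclohexyl in place of chloro gives a 2.0-fold higher number from compound 1 to compound 4 (0.31 log units; beyond the scatter), and cyclohexyl in place of phenyl gives a 2.6-fold higher number from compound 2 to compound 4 (0.42 log units; beyond the scatter), both modest. The non-aromatic ring does not separate cleanly from the aromatic groups, however, since cyclohexyl in place of 2-(trifluoromethyl)pyridin-4-yl gives a 2.0-fold higher number from compound 3 to compound 4 (0.30 log units; within the scatter), so compound 3 goes against any clean split between the ring types. Nothing available explains these steps.

Open, as far as these compounds go, is whether a piperidine or morpholine ring, a cyclopropyl group or a carboxylic acid at this position would stay with compound 1 or follow compound 4. From the compounds shown here alone, all four compounds also share one core, so whether the cyclohexyl step holds on another core remains open.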